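Fluoro for Methyl: What to Expect of Compound 3

The source may hold more compounds than are shown below. What is called first, only, known or untested is meant among the compounds shown, and "the series" means these compounds.

Compound 1 `Cc1ccc2nc(C(=O)Nc3c(F)cc(-c4cccc(F)c4)cc3F)c(C)c(O)c2c1` and compound 2 `Cc1ccc2nc(C(=O)Nc3c(F)cc(-c4cccc(F)c4)cc3F)c(C)c(C(=O)O)c2c1` share one core and differ in a single place. Among the measured compounds shown here, in a functional assay on A-375 cells (Homo sapiens) for antiproliferative activity, read by MTT assay, with a stated time of 24 h, tested at 100 ug/mL (on this read-out lower numbers stand for a weaker effect and higher numbers for a stronger effect at the one concentration tested), compound 1 gives 56.4%, while compound 2 gives 37.3%; the one measured step, a number 19.1 percentage points lower from compound 1 to compound 2 (beyond the scatter), arises from a carboxy in place of hydroxy on an aromatic carbon. For the measured compounds named here, on these two numbers compound 2 stands lowest, with compound 1 as its only neighbour.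

Compound 3 `Cc1c(C(=O)Nc2c(F)cc(-c3cccc(F)c3)cc2F)nc2ccc(F)cc2c1C(=O)O` keeps the carboxy of compound 2 and differs from it by fluoro in place of methyl on an aromatic carbon. Going by the values given here, no measured step concerns this change: the only step available, a number 19.1 percentage points lower from compound 1 to compound 2 (beyond the scatter), alters a different group and so says nothing about fluoro in place of methyl. Lacking a comparable step, the step of a number 0.7 percentage points higher from compound 2 to compound 3 (within the scatter) is expected to stay within the scatter. Compound 3 is therefore estimated in this assay at 38%, within a range from 22% to 54%.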

Compound 3, a percentage reported as inhibition, at one concentration (the size of the read-out at that concentration, not a potency): 64.3%
Compound 3: the middle estimate sits 26.3 percentage points below what was measured; the whole stated range lies below it.
By their numbers in this assay, from the lowest: compound 2; then compounds 1 and 3 (each within the scatter of the next).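

With the carboxy kept in place, fluoro in place of methyl on an aromatic carbon gives a number 27 percentage points higher from compound 2 to compound 3 (beyond the scatter) in this assay, so this position on the shared core is not indifferent to what it carries. The earlier step concerned only the exchange of hydroxy and carboxy; this one shows that a second place, on the six-membered aromatic ring of carbon only, also moves the read-out beyond the scatter, with one heavy atom exchanged for another. No evidence at hand bears on why the number rises with this change.

On these data alone, whether the rise belongs to fluoro itself or to the loss of methyl stays open, and chloro, methoxy or plain hydrogen at this position would separate the two. The compounds shown also leave open whether the same exchange holds with hydroxy in place of the carboxy.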